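The compounds below may be only part of what the source reports. "The series", "measured", "known", "first", "only" and "open" are said of these compounds alone.

- compound 1 `O=C(/C=C/c1ccccc1)NNC(=O)c1ccccc1O`: 41400 nM
- compound 2 `O=C(COC(=O)/C=C/c1ccc(O)c(O)c1)NN1CCOCC1`: > 200000 nM

Both compounds were tested in a functional assay on ECa-109 cells (Homo sapiens) for cytotoxicity, read by MTT assay, with a stated time of 72 h; on this read-out lower numbers stand for stronger inhibition and higher numbers for weaker inhibition. Compound 1 gives a true measured number there, 41400 nM. Compound 2 gives > 200000 nM, which is a limit of the assay and not a number. Compound 2 therefore stands at the end of the measurable range, as the limit of > 200000 nM in this assay, at which 1 of the 2 values shown sits, records.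

Compound 3 `COc1ccc(NC(=O)COC(=O)/C=C/c2ccc(O)c(O)c2)cc1` is related to compound 2 by a single change: 4-methoxyphenyl in place of morpholin-4-yl on an amide-type nitrogen. Among the compounds with values here, no measured pair shows what this exchange does in this assay, so any expectation is tentative. A move toward stronger inhibition, of moderate size, is expected, with compound 1 at 41400 nM as the only numerical reference. The expected change is an at least 3.3-fold lower number from compound 2 to compound 3 (0.52 log units; beyond the scatter). For compound 3 the estimated value is 60000 nM, with an expected range from 15000 nM to 180000 nM.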

Compound 3, half-maximal inhibitory concentration: 190000 nM
Compound 3: middle estimate off by 3.2-fold (0.50 log units), on the low side, outside the stated range (above it).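

Putting 4-methoxyphenyl in place of morpholin-4-yl on the amide-type nitrogen brings this series onto the measurable scale: in this assay compound 3 gives 190000 nM, a true number. Compound 2 remains a limit of the assay, at > 200000 nM. The change therefore reads only as an at least 1.0-fold lower number from compound 2 to compound 3 (0.02 log units; that floor lies within the scatter), and its real size stays open because the starting point is a limit: the limit of > 200000 nM in this assay, at which 1 of the 3 values shown sits.

The compounds shown leave open how other groups on this amide-type nitrogen, such as a benzyl group or a piperidin-1-yl ring, would read in this assay. They also leave open whether the methoxy group of the 4-methoxyphenyl matters, which a 4-chlorophenyl group on the same nitrogen could help to separate from the effect of the aromatic ring itself.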